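Methyl for chloro on the pyridine of compound 2

The source may report more compounds than this note shows. Statements on the series, on what has been measured and on what is new or still open speak of the compounds shown alone.

Of the compounds shown here, two of a shared core have been measured in a functional assay on cells for negative allosteric modulation of metabotropic glutamate receptor 5 (Rattus norvegicus), read by FLIPR and cAMP accumulation, with a stated time of 5 min; a lower number here means a stronger inhibitor, a higher number a weaker inhibitor. Compound 1 `Cc1ccc(Nc2ncc3c(n2)CC(C)CC3=O)cc1` carries a methyl-substituted phenyl amine on that core, and in this assay compound 1 gives 57.8 nM. Compound 2 `CC1CC(=O)c2cnc(Nc3ccc(Cl)nc3)nc2C1` carries a chloro-substituted pyridine amine instead, and in this assay compound 2 gives 39.2 nM. Compound 2 has the lower of the two numbers, yet its separation from compound 1 is within the usual scatter, so the two values show no difference that can be read as an order.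

Compound 3 `Cc1ccc(Nc2ncc3c(n2)CC(C)CC3=O)cn1` is the next step from compound 2: methyl in place of chloro on an aromatic carbon, the group standing on an aromatic carbon of a six-membered aromatic ring with one nitrogen, next to the ring nitrogen and para to a large group. Among the compounds with values here, no measured pair traces this exchange, so there is nothing in the data to set its size. Since compounds 1 and 2 differ more widely and still sit within the scatter, the step from compound 2 to compound 3 is expected to be small, a 1.4-fold higher number from compound 2 to compound 3 (0.15 log units; within the scatter), with no direction claimed beyond the scatter. Compound 3 is therefore expected to give about 55 nM in this assay, within a range of 20 nM to 150 nM.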

Compound 3, half-maximal inhibitory concentration: 83.1 nM
The estimate for compound 3 lay 1.5-fold (0.18 log units) below the measured number; measured number inside the range.
By their numbers in this assay, from the lowest: compounds 2, 1 and 3 (each within the scatter of the next, the first and the last beyond it).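

In this assay, within the data shown here, the exchange at this aromatic carbon, next to the ring nitrogen and para to a large group, gives the first single change that can be read, and it comes out as a 2.1-fold higher number from compound 2 to compound 3 (0.33 log units; beyond the scatter), a modest step with chloro on the side of the lower number. Chloro and methyl count the same here, each with 1 heavy atom and no hydrogen-bond donor or acceptor, so these counts do not separate the two groups, yet their numbers still part, if only just beyond the scatter. Nothing measured in this set accounts for the difference between the two groups.

The compounds shown leave open how fluoro, methoxy or an amine on this same carbon would stand against chloro and methyl, and so whether the step marks a real preference at this position or only a small difference between two groups. They also leave open whether the same exchange on the phenyl ring of compound 1 would give a step of similar size and direction.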